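Swapping a Substituted Phenyl for a Pyridine

The compounds below may be only part of what the source reports. "The series", "measured", "known", "first", "only" and "open" are said of these compounds alone.

Measured values:
- compound 1 `COC(=O)c1ccc(N2CC3(CCN(C(=O)c4cc(C)c5[nH]ncc5c4)CC3)CC2=O)cc1` gives 5640 nM
- compound 2 `O=C(c1ccc2[nH]c(-c3ccccc3)nc2c1)N1CCC2(CC1)CC(=O)N(c1ccc(C(F)(F)F)cc1)C2` gives 380 nM
- compound 3 `CC(C)c1ccc(-c2nc3cc(C(=O)N4CCC5(CC4)CC(=O)N(c4ccc(C(F)(F)F)cc4)C5)ccc3[nH]2)cc1` gives > 10000 nM (a limit, not a number)

In a functional assay on NCI-H1975 cells (Homo sapiens) for antiproliferative activity, read by MTT assay, with a stated time of 48 h (a lower number here means a stronger inhibitor, a higher number a weaker inhibitor), compound 3 reads > 10000 nM and this is a limit, not a number. That places it at the limit of > 10000 nM in this assay, at which 1 of the 3 values shown sits.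

Compound 4 `O=C(c1ccc2[nH]c(-c3ccncc3)nc2c1)N1CCC2(CC1)CC(=O)N(c1ccc(C(F)(F)F)cc1)C2` has one change from compound 3: pyridin-4-yl in place of 4-isopropylphenyl on an aromatic carbon of the five-membered aromatic ring with 2 nitrogen, (pyridin-4-yl in place of 4-isopropylphenyl on an aromatic carbon).

Among the compounds with values here, one measured step bears on this change. It is an at least 26-fold higher number from compound 2 to compound 3 (1.42 log units; beyond the scatter), a large step beyond the scatter, made by isopropyl in place of hydrogen on an aromatic carbon. Compound 4 has no isopropyl, so a large step to a lower number is expected, with compound 2 at 380 nM as the closest guide. Within the data shown here, no measured step covers the ring nitrogen, so the expected range stays wide.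

The expected change is an at least 11-fold lower number from compound 3 to compound 4 (1.04 log units; beyond the scatter), and it is only an estimate.

For compound 4 the estimated value is 900 nM, expected to fall from 200 nM to 4000 nM.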

Compound 4, half-maximal inhibitory concentration: 390 nM
The estimate for compound 4 lay 2.3-fold (0.36 log units) above the measured number; measured number inside the range.
By their numbers in this assay, from the lowest: compounds 2 and 4 (each within the scatter of the next); then compound 1. At a limit, above all of these: compound 3.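

In this assay, pyridin-4-yl in place of phenyl on the aromatic carbon between two ring nitrogen atoms gives a 1.0-fold higher number from compound 2 to compound 4 (0.01 log units; within the scatter), so this ring nitrogen makes no difference that the read-out can separate from the scatter. Pyridin-4-yl in place of 4-isopropylphenyl gives an at least 25-fold lower number from compound 3 to compound 4 (1.40 log units; beyond the scatter), which shows that a large loss seen with the isopropyl group does not extend to this unsubstituted pyridine ring. Compound 3 reads as a limit, not a number, so the true size of that step remains unknown: the limit of > 10000 nM in this assay, at which 1 of the 4 values shown sits.

Still open, from the compounds shown here alone, is whether methyl, an amine or a carboxylic acid in the place of isopropyl would also cost activity. Also open, going by these compounds, is whether pyridin-3-yl would match pyridin-4-yl, which would show whether the place of the nitrogen matters.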